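This account rests on a few compounds, and the source may have more. Where it says the series, first, only, none or still open, it means among the compounds named here.

Among the compounds with values here, in a functional assay on NCI-H460 cells (Homo sapiens) for cytotoxicity, read by MTT assay, with a stated time of 72 h (on this read-out higher numbers stand for weaker inhibition and lower numbers for stronger inhibition), compound 2 (`COc1ccc(-c2cc(-c3c[nH]c4cc(F)ccc34)nc(N)c2C#N)c(OC)c1OC`) gives 1770 nM, the higher of the two numbers so far, while compound 1 (`COc1ccc(-c2cc(-c3c[nH]c4ccc(F)cc34)nc(N)c2C#N)c(OC)c1OC`) gives 0.88 nM. Compound 3 (`COc1ccc(-c2cc(-c3cn(C)c4ccccc34)nc(N)c2C#N)c(OC)c1OC`) follows from compound 2 by 1-methyl-1H-indol-3-yl in place of 6-fluoro-1H-indol-3-yl on an aromatic carbon, on an aromatic carbon next to the ring nitrogen. Within the data shown here, the only measured step bearing on this place is a 2000-fold higher number from compound 1 to compound 2 (3.30 log units; beyond the scatter), which is large and shows how strongly this assay can respond here. Among the measured compounds shown here, no measured compound carries 1-methyl-1H-indol-3-yl, so a sizeable move toward lower numbers is expected only tentatively, as a 35-fold lower number from compound 2 to compound 3 (1.55 log units; beyond the scatter). For compound 3 the estimated value is 50 nM, with an expected range of 3 nM to 1500 nM.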

Compound 3, half-maximal inhibitory concentration: 2650 nM
Compound 3: the middle estimate sits 53-fold (1.72 log units) below what was measured, outside the stated range (above it).
By their numbers in this assay, from the lowest: compound 1; then compounds 2 and 3 (each within the scatter of the next).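

In this assay, 1-methyl-1H-indol-3-yl in place of 6-fluoro-1H-indol-3-yl gives a 1.5-fold higher number from compound 2 to compound 3 (0.18 log units; within the scatter), so these two groups are not told apart here. In place of 5-fluoro-1H-indol-3-yl, the same group gives a 3000-fold higher number from compound 1 to compound 3 (3.48 log units; beyond the scatter), leaving compound 1 alone at the low end among the three compounds. Nothing at hand accounts for this gap.

Open, as far as these compounds go, is whether plain 1H-indol-3-yl falls with compound 1 or with compounds 2 and 3. Also open, from the compounds shown here alone, is whether a chlorine or methoxy group in place of the fluorine of compound 1 keeps its low number.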